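Swapping fluoro for methyl on the benzyl ring

This account rests on a few compounds, and the source may have more. Where it says the series, first, only, none or still open, it means among the compounds named here.

Measured so far:
compound 1 `CC(=O)c1cccc(OCc2cccc(F)c2)c1` gives 31%
compound 2 `CC(=O)c1cccc(OCc2ccc(F)cc2)c1` gives 49.6%
compound 3 `CC(=O)c1cccc(OCc2cccc(C)c2)c1` gives 31.1%

All three were tested in an assay on isolated protein for inhibition of Amine oxidase [flavin-containing] A (Homo sapiens), read by Amplex Red, with a stated time of 15 min, tested at 100 uM; a higher number here means more inhibition at the concentration tested (going by the name of the read-out), a lower number less inhibition. Compound 1 and compound 2 are built from the same atoms joined differently; the difference between the two cores is not broken down here. Compound 2 stands highest of the three, and its lead over compound 3 and over compound 1 lies beyond the scatter of this assay.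

One change has already been made once and measured: from compound 1 to compound 3 fluoro gives way to methyl, (methyl in place of fluoro on an aromatic carbon). That step, a number 0.1 percentage points higher from compound 1 to compound 3 (within the scatter), is flat and lies within the scatter.

Compound 4 `CC(=O)c1cccc(OCc2ccc(C)cc2)c1` is not yet measured. It comes from compound 2 by the same kind of change, (methyl in place of fluoro on an aromatic carbon). The surroundings differ, though: in compound 1 the group sits meta to a large group, whereas in compound 2 it sits para to a large group, so the earlier step is only a guide, not a copy.

Resting on the flat step from compound 1 to compound 3 and on the value of compound 2, 49.6%, the expected step in this assay is a number 2.6 percentage points lower from compound 2 to compound 4 (within the scatter). Compound 4 is therefore estimated at 47%, most likely between 30% and 62%.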

Compound 4, a percentage reported as inhibition, at one concentration (the size of the read-out at that concentration, not a potency): 23%
For compound 4 the middle estimate is 24 percentage points above the measured one; the whole stated range lies above it.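

In this assay, methyl in place of fluoro did not behave in the same way on the two cores, and with the group para to a large group the step is a number 26.6 percentage points lower from compound 2 to compound 4 (beyond the scatter). Set beside the earlier step, this result shows that the flat outcome from the first pair cannot simply be carried over to the second, since the two steps differ by more than repeated measurements would be expected to: the same change on two cores in this assay, a number 0.1 percentage points higher (within the scatter) from compound 1 to compound 3 and a number 26.6 percentage points lower (beyond the scatter) from compound 2 to compound 4, 26.7 percentage points apart, beyond the scatter of two such steps Two pairs are still too few to give a rule for this change, and they do not say why it lowers inhibition in one setting and leaves it flat in the other; each number is also the size of a read-out at one concentration, not a potency.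

The compounds shown leave open how other groups in the same place, such as chloro, methoxy or an amine, would compare on either core. They also leave open whether the swap from fluoro to methyl would give the same split if the acetyl group on the other ring gave way to an amide or a carboxylic acid.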